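The compounds below may be only part of what the source reports. "The series", "measured", "known", "first", "only" and "open" are said of these compounds alone.

Compound 1 `CCCC[N+](C)(C)CCCC(=O)[O-]` is the open-chain member of this small set. In an assay for inhibition of gamma-butyrobetaine dioxygenase (Homo sapiens), read by HPLC, with stated times of 15 min and 30 min (on this read-out lower numbers stand for stronger inhibition and higher numbers for weaker inhibition), compound 1 gives > 1000000 nM, which is a limit of the assay and not a number. Compound 2 `C[N+](C)(CCCC(=O)[O-])C1CCC1` carries a cyclobutyl on the amine nitrogen, and in this assay compound 2 gives 810 nM. Compound 3 `C[N+](C)(CCCC(=O)[O-])C1CCCC1`, with a cyclopentyl in the same place, gives > 1000000 nM in this assay, again a limit rather than a number. Among the compounds with values here, compound 1 thus stands at the limit (the limit of > 1000000 nM in this assay, at which 2 of the 3 values shown sit), together with compound 3, while compound 2 is the only member with a measured value.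

Compound 4 `C[N+](C)(CCCC(=O)[O-])CC1CCC1` differs from compound 1 by cyclobutyl in place of propyl on a saturated chain carbon bound to an amine nitrogen. Within the data shown here, the only measured step that bears on it is the one from the butyl to the cyclobutyl, an at least 1200-fold lower number from compound 1 to compound 2 (3.09 log units; beyond the scatter). Compound 4 keeps the four-membered ring of compound 2 but moves it one carbon away from the nitrogen, and compound 3 shows that a larger ring on the nitrogen returns to the limit. Compound 4 is therefore expected to lie in this assay at about 300000 nM, between 5000 nM and 1000000 nM. Such a value would mean an estimated step of an at least 3.3-fold lower number from compound 1 to compound 4 (0.52 log units; beyond the scatter).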

Compound 4, half-maximal inhibitory concentration: > 1000000 nM
Compound 4 was reported as a limit (the forecaster's own chance of this, stated with the estimate: 50%); middle value at least 3.3-fold (0.52 log units) from the limit.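

In this assay compound 4 gives > 1000000 nM, which is a limit and not a number; compound 1 also stands at a limit, so the step between them cannot be read: the limit of > 1000000 nM in this assay, at which 3 of the 4 values shown sit.

The compounds shown leave open what actual numbers compound 1, compound 3 and compound 4 would give, and so how they rank among themselves.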